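Guanidine substituent variation in a pyridyl-aryl butyl series

The compounds below may be only part of what the source reports. "The series", "measured", "known", "first", "only" and "open" are said of these compounds alone.

Measured compounds: compound 1 `Brc1ccc(C(CC/N=C(/NCCCc2c[nH]cn2)Nc2ccccc2)c2ccccn2)cc1`, compound 2 `N=C(NCCCc1c[nH]cn1)NCCCC(c1ccc(Cl)c(Cl)c1)c1ccccn1`, compound 3 `CN/C(=N\CCCC(c1ccc(Cl)c(Cl)c1)c1ccccn1)NCCCc1c[nH]cn1`.

In a functional assay on ileum for antagonist activity at histamine H1 receptor (Cavia porcellus) (a higher number here means a more potent compound, by a factor of ten per unit of this negative logarithm, a lower number a less potent compound), compound 1 gives 5.81, compound 2 gives 7.46, and compound 3 gives 6.16. Compound 3 thus stands second highest of the three, above compound 1 but well below compound 2.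

Compound 4 `Clc1ccc(C(CCC/N=C(/NCCCc2c[nH]cn2)Nc2ccccc2)c2ccccn2)cc1Cl` differs from compound 3 by phenyl in place of methyl on an amine nitrogen. Within the data shown here, no measured pair isolates this change. Compound 1 carries the same anilino group, yet on a different core, so it gives only a loose pointer. A step is expected that is small, leaning downward, and not clearly beyond the scatter: a number 0.16 log units lower from compound 3 to compound 4 (within the scatter). For compound 4 in this assay the estimate is 6, with a range from 5.3 to 6.8.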

Compound 4, negative logarithm of the antagonist equilibrium constant: 5.5
Compound 4: middle estimate off by 0.50 log units, on the high side, within the range that was stated.
By their numbers in this assay, from the lowest: compound 4; then compound 1; then compound 3; then compound 2.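

Among these compounds, on the shared core, phenyl in place of methyl on an amine nitrogen gives, in this assay, a number 0.66 log units lower from compound 3 to compound 4 (beyond the scatter), the first isolated reading of the methylamino to anilino change. Compound 2, with neither group on this nitrogen, gives 7.46, so the printed values place both substituted compounds lower. No available measurement accounts for the fall in potency.

Still open, from the compounds shown here alone, is where an ethyl or a benzyl group on this nitrogen would fall relative to methyl and phenyl. Equally open, going by these compounds, is whether a methylamino group would also read higher than anilino on the core of compound 1.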